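The source may hold more compounds than are shown below. What is called first, only, known or untested is meant among the compounds shown, and "the series" means these compounds.

Measured in an ADME assay on HEK293 cells (Homo sapiens) for cytotoxicity, read by MTT assay, with a stated time of 48 h; a lower number here means a stronger inhibitor, a higher number a weaker inhibitor:
compound 1 `COc1ccc(/C=C2/S/C(=N/c3ccccc3)N(Cc3ccncc3)C2=O)cc1`: 47900 nM
compound 2 `O=C1/C(=C\c2cccc(Cl)c2)S/C(=N/c2ccccc2)N1Cc1ccncc1`: 71800 nM

Within the data shown here, compound 2 does not separate from the only other measured compound, and the two numbers lie within the scatter of each other. Next comes compound 3 `O=C1/C(=C\c2ccccn2)S/C(=N/c2ccccc2)N1Cc1ccncc1`, with pyridin-2-yl in place of 3-chlorophenyl on a double-bonded chain carbon bound to a double-bonded ring carbon. Among the measured compounds shown here, one measured step bears on this place, with 3-chlorophenyl in place of 4-methoxyphenyl: a 1.5-fold higher number from compound 1 to compound 2 (0.18 log units; within the scatter). For the measured compounds named here, no measured compound carries pyridin-2-yl at this place, so the guide is thin. With that single step as the basis, no step beyond the scatter is expected in this assay, in either direction. The expected step is a 1.2-fold lower number from compound 2 to compound 3 (0.08 log units; within the scatter). For compound 3 the estimate is 60000 nM, with an expected range of 25000 nM to 130000 nM.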

Compound 3, half-maximal inhibitory concentration: 161000 nM
Estimate against measurement, compound 3: 2.7-fold (0.43 log units) below; measured number outside the range, above it.
By their numbers in this assay, from the lowest: compounds 1 and 2 (each within the scatter of the next); then compound 3.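

In this assay, the place on a double-bonded chain carbon bound to a double-bonded ring carbon now shows a change beyond the scatter: pyridin-2-yl in place of 3-chlorophenyl gives a 2.2-fold higher number from compound 2 to compound 3 (0.35 log units; beyond the scatter), and pyridin-2-yl in place of 4-methoxyphenyl gives a 3.4-fold higher number from compound 1 to compound 3 (0.53 log units; beyond the scatter). The two carbon-only aromatic rings did not separate from each other, whereas the ring with a hetero atom separates from both, with modest steps in the same direction. Nothing available bears on the reason for this shift.

On these data alone, whether the shift follows the ring nitrogen itself or its location in the ring remains open, a question that pyridin-3-yl and pyridin-4-yl would address. Also open, as far as these compounds go, is how an amine or a carboxylic acid on the phenyl ring at this place would move the number.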